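Moving the methyl around the anilide ring of compound 3

A few compounds are considered here, and "the series" means these few. Any claim that something is new, unique, unknown or untested is made for them only; others in the source may bear on it.

Three anilides on a shared core have been tested in a functional assay on the whole organism (strain Wistar) for inhibition, with Rattus norvegicus as the target, read by paw edema, with a stated time of 3 h, at a dose of 100 mg/kg; on this read-out lower numbers stand for less inhibition and higher numbers for more inhibition at the one dose given (going by the name of the read-out). Compound 1 `COc1cc2c(cc1OC)C(CC(=O)Nc1ccccc1)CC2` gives 36.2%. Compound 2 `COc1cc2c(cc1OC)C(CC(=O)Nc1ccc(Cl)cc1)CC2` gives 60.9%, and compound 3 `COc1cc2c(cc1OC)C(CC(=O)Nc1ccccc1C)CC2` gives 26.1%. Compound 3 therefore stands lowest of the three: a number 10.1 percentage points lower from compound 1 to compound 3 (beyond the scatter), and a number 34.8 percentage points lower from compound 2 to compound 3 (beyond the scatter).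

Compound 4 `COc1cc2c(cc1OC)C(CC(=O)Nc1cccc(C)c1)CC2` is not yet measured. It differs from compound 3 in one place only: 3-methylphenyl in place of 2-methylphenyl on an amide-type nitrogen.

Among the compounds with values here, no measured step moves a methyl group from one aromatic carbon to another, so the bearing of the existing steps is indirect. Within the data shown here, the one methyl step, a number 10.1 percentage points lower from compound 1 to compound 3 (beyond the scatter), was modest and downward. Among the measured compounds shown here, the one step that changed the substituent on the anilide ring in a different way, a number 24.7 percentage points higher from compound 1 to compound 2 (beyond the scatter), was modest and upward. The large step of a number 34.8 percentage points lower from compound 2 to compound 3 (beyond the scatter) mixes both the kind of group and its position. With nothing that isolates the position of the methyl, the writer expects compound 4 to land near compound 1 and compound 3, with a step of a number 9.9 percentage points higher from compound 3 to compound 4 (within the scatter) in this assay that is expected to fall within the scatter. The estimate for compound 4 in this assay is 36%, expected to lie between 18% and 55%.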

Compound 4, a percentage reported as inhibition, in the whole organism at one dose (the size of the read-out at that dose, not a potency): 37.7%
Beside the measured number, compound 4's estimate is 1.7 percentage points below it, within the range that was stated.
By their numbers in this assay, from the lowest: compound 3; then compounds 1 and 4 (each within the scatter of the next); then compound 2.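

Within the data shown here, this is the first step that changes only where the methyl sits on the anilide ring, and in this assay that place matters: a number 11.6 percentage points higher from compound 3 to compound 4 (beyond the scatter), so 3-methylphenyl and 2-methylphenyl on the amide-type nitrogen do not read alike. Set against the ring without a methyl, 3-methylphenyl shows no difference that stands clear of the scatter, a number 1.5 percentage points higher from compound 1 to compound 4 (within the scatter), so among these anilides the earlier downward methyl step goes with 2-methylphenyl and not with methyl wherever it sits. The gain seen with 4-chlorophenyl stays out of reach, a number 23.2 percentage points lower from compound 2 to compound 4 (beyond the scatter), although that step changes both the kind of group and its place on the ring.

Nothing measured here explains why the place of the methyl changes the reading. The compounds shown also leave open whether a methyl in the place the chlorine holds in compound 2 would keep that higher reading, and how a methoxy group or an amine on the anilide ring would read in this assay.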